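The source may report more compounds than this note shows. Statements on the series, on what has been measured and on what is new or still open speak of the compounds shown alone.

Compound 1 `C[C@H]1CO[C@]2(C)Oc3c(c4c(c5c3C[C@@H]3[C@@H](C)CO[C@]3(C)O5)C[C@@H]3[C@@H](C)CO[C@]3(C)O4)C[C@H]12`: 31000 nM
Compound 2 `C#CCOc1cc2c(c3c1C[C@@H]1[C@@H](C)CO[C@]1(C)O3)C[C@@H]1[C@@H](C)CO[C@]1(C)O2`: 22000 nM

In a functional assay on aorta (Rattus norvegicus, strain Sprague-Dawley) for inhibition (on this read-out higher numbers stand for an effect only at larger amounts of compound and lower numbers for an effect already at smaller amounts), compound 1 gives 31000 nM, and compound 2 gives 22000 nM, the lower of the two numbers, though the gap to compound 1 lies within the scatter. Compound 3 `CCCCOc1cc2c(c3c1C[C@@H]1[C@@H](C)CO[C@]1(C)O3)C[C@@H]1[C@@H](C)CO[C@]1(C)O2` differs from compound 2 by propyl in place of ethynyl on a saturated chain carbon bound to an oxygen on an aromatic ring. Going by the values given here, no step between measured compounds covers such a change, so the step of a 1.1-fold higher number from compound 2 to compound 3 (0.06 log units; within the scatter) is expected to stay within the scatter. Compound 3 is therefore estimated in this assay at 25000 nM, within the range 8000 nM to 70000 nM.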

Compound 3, half-maximal effective concentration: > 200000 nM
Compound 3: no number, only a limit (the forecaster's own chance of this, stated with the estimate: 10%); at least 8.0-fold (0.90 log units) between middle value and limit.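

Going by these compounds alone, at this place, on a saturated chain carbon bound to an oxygen on an aromatic ring, propyl in place of ethynyl brings an at least 9.0-fold higher number from compound 2 to compound 3 (0.95 log units; beyond the scatter), so the read-out in this assay responds clearly to this change, which the earlier compounds could not show. The size of this step is only a lower bound: the limit of > 200000 nM in this assay, at which 1 of the 3 values shown sits.

From the compounds shown here alone, with only compound 2 and compound 3 at this place, it stays open whether the triple bond or the chain length matters more. Going by these compounds, how an allyl group, a shorter ethyl chain or a terminal amine would read at this place also stays open.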